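The source may hold more compounds than are shown below. What is called first, only, known or untested is meant among the compounds shown, and "the series" means these compounds.

Compound 3, `O=c1c(S(=O)(=O)c2ccc(F)cc2F)cc2cnc(Nc3ccc4[nH]ccc4c3)nc2n1CC1CCCC1`, carries a cyclopentylmethyl group on an aromatic nitrogen of the shared core. Within the data shown here, in a functional assay on DU-145 cells (Homo sapiens) for inhibition, read by trypan blue exclusion, with a stated time of 72 h (on this read-out higher numbers stand for weaker inhibition and lower numbers for stronger inhibition), compound 3 gives 10000 nM, the second highest of the three numbers measured so far. Compound 1, `O=c1c(S(=O)(=O)c2ccc(F)cc2F)cc2cnc(Nc3ccc4[nH]ccc4c3)nc2n1C1CC1`, gives 500 nM, and compound 2, `O=c1[nH]c2nc(Nc3ccc4[nH]ccc4c3)ncc2cc1S(=O)(=O)c1ccc(F)cc1F`, gives 15000 nM. Compound 4, `O=c1c(S(=O)(=O)c2ccc(F)cc2F)cc2cnc(Nc3ccc4[nH]ccc4c3)nc2n1C1CCCCC1`, differs from compound 3 only at that nitrogen: cyclohexyl in place of cyclopentylmethyl on an aromatic nitrogen. Among the measured compounds shown here, two measured steps bear on this position. a 20-fold higher number from compound 1 to compound 3 (1.30 log units; beyond the scatter) and a 1.5-fold lower number from compound 2 to compound 3 (0.18 log units; within the scatter) show that the group here matters, since cyclopropyl stands far below both hydrogen and cyclopentylmethyl, while those two sit close together. For the measured compounds named here, with no direct precedent for cyclohexyl, the step of a 2.0-fold lower number from compound 3 to compound 4 (0.30 log units; within the scatter) is expected to be modest. Compound 4 is therefore estimated at 5000 nM, with a range from 1500 nM to 15000 nM.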

Compound 4, half-maximal inhibitory concentration: 10000 nM
For compound 4 the middle estimate is 2.0-fold (0.30 log units) below the measured one; low and high end bracket the measured number.
By their numbers in this assay, from the lowest: compound 1; then compounds 3, 4 and 2 (each within the scatter of the next).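

In this assay, replacing cyclopentylmethyl with cyclohexyl, which has the same count of heavy atoms but a six-membered ring, gives no change at the digits printed from compound 3 to compound 4 (within the scatter). Compound 4 also stays close to the hydrogen-bearing compound, with a 1.5-fold lower number from compound 2 to compound 4 (0.18 log units; within the scatter), whereas a 20-fold higher number from compound 1 to compound 4 (1.30 log units; beyond the scatter) confirms that, among these four compounds, only cyclopropyl stands apart, with the lowest number. No measurement here explains why cyclopropyl differs. As far as these compounds go, whether the low number is special to cyclopropyl remains open, and methyl, cyclobutyl or an amine on a short chain at this nitrogen could help to settle it.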